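A few compounds are considered here, and "the series" means these few. Any claim that something is new, unique, unknown or untested is made for them only; others in the source may bear on it.

Measured so far:
Compound 1, `O=[N+]([O-])C1=NNc2ncnn2C1c1ccc(O)c(O)c1O`, in an ADME assay on MDCK cells (Canis lupus familiaris) for cytotoxicity (on this read-out lower numbers stand for higher toxicity in this test and higher numbers for lower toxicity in this test), gives 228000 nM.
Compound 2, `O=[N+]([O-])C1=CNc2ncnn2C1c1ccc(O)c(O)c1O`, in this assay gives 405000 nM.
Compound 3, `O=[N+]([O-])C1=NNc2nc(C(F)(F)F)nn2C1c1ccc(O)c(O)c1O`, in this assay gives 67000 nM.

The difference between the core of compound 1 and the core of compound 2 is not broken down here. Compound 3 carries one change on the core of compound 1: trifluoromethyl in place of hydrogen on an aromatic carbon. This change made the step of a 3.4-fold lower number from compound 1 to compound 3 (0.53 log units; beyond the scatter). Compound 4, `O=[N+]([O-])C1=CNc2nc(C(F)(F)F)nn2C1c1ccc(O)c(O)c1O`, carries the same change on the core of compound 2: trifluoromethyl in place of hydrogen on an aromatic carbon. The place of the change is the same in both pairs. Because compound 1 to compound 3 gave a 3.4-fold lower number from compound 1 to compound 3 (0.53 log units; beyond the scatter), a step of similar size, a 3.4-fold lower number from compound 2 to compound 4 (0.53 log units; beyond the scatter), is expected in this assay from compound 2 to compound 4. Compound 4 is therefore estimated at 120000 nM, with a likely range from 60000 nM to 240000 nM.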

Compound 4, half-maximal cytotoxic concentration: 373000 nM
Compound 4: middle estimate off by 3.1-fold (0.49 log units), on the low side; the measured number lies above the stated range.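

In this assay, trifluoromethyl in place of hydrogen on an aromatic carbon did not give the same result on both cores, and the new step is a 1.1-fold lower number from compound 2 to compound 4 (0.04 log units; within the scatter). The size of the step therefore did not carry over from one core to the other: the same change on two cores in this assay, a 3.4-fold lower number (0.53 log units; beyond the scatter) from compound 1 to compound 3 and a 1.1-fold lower number (0.04 log units; within the scatter) from compound 2 to compound 4, 3.1-fold (0.50 log units) apart, beyond the scatter of two such steps. This shows that a step measured on one core in this series cannot simply be applied to another, but a single pair of steps does not show which difference between the cores matters.

The compounds shown leave open whether a methyl group or an amine in the same place would also give different steps on the two cores. They also leave open how trifluoromethyl would behave on a third core.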